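The source may report more compounds than this note shows. Statements on the series, on what has been measured and on what is new or still open speak of the compounds shown alone.

Measured so far:
- compound 1 `CCCOc1ccc(C(=O)Nc2cccc(C)n2)cc1`: 11100 nM in an in vitro assay on HEK-tsA201 cells for antagonist activity at Neuronal acetylcholine receptor; alpha3/beta4 (Homo sapiens), read by fluorescence and calcium flux; on this read-out higher numbers stand for weaker inhibition and lower numbers for stronger inhibition
- compound 2 `CCCOc1ccc(C(=O)Nc2cccc(Nc3ccccc3)n2)cc1`: reported only as a limit, > 100000 nM in this assay

Going by the values given here, compound 2 thus stands at the upper limit of this assay, and the limit of > 100000 nM in this assay, at which 1 of the 2 values shown sits, is the only evidence on it. Among the compounds with values here, the one measured step, an at least 9.0-fold higher number from compound 1 to compound 2 (0.95 log units; beyond the scatter), took the series from a number to that limit. Compound 3 `CCCOc1ccc(C(=O)Nc2cccc(N3CCCCC3)n2)cc1` carries the change (piperidin-1-yl in place of anilino on an aromatic carbon); the group that leaves is the one that entered in that step, so the change bears on it only loosely. Compound 3 is therefore expected to give about 80000 nM, within 20000 nM to 300000 nM. The expected step is an at least 1.2-fold lower number from compound 2 to compound 3 (0.09 log units; that floor lies within the scatter).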

Compound 3, half-maximal inhibitory concentration: > 100000 nM
Compound 3: only a limit was reported; the forecaster's own chance of this, stated with the estimate: 55%; at least 1.2-fold (0.09 log units) between middle value and limit.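

In this assay, piperidin-1-yl in place of methyl on the aromatic carbon next to the ring nitrogen gives an at least 9.0-fold higher number from compound 1 to compound 3 (0.95 log units; beyond the scatter), so a group with no aromatic ring and no hydrogen-bond donor also ends in a limit rather than a number. Compound 2 and compound 3 are both reported as limits, and the step between them cannot be read. The two larger groups therefore cannot be ranked: the limit of > 100000 nM in this assay, at which 2 of the 3 values shown sit.

As far as these compounds go, whether ethyl, methoxy or a plain amine at this position would keep a measurable number remains open. So does whether any such group would give a lower number than compound 1.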